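Triazole Attachment Swapped on a Shared Core

The source may report more compounds than this note shows. Statements on the series, on what has been measured and on what is new or still open speak of the compounds shown alone.

Compound 1 `CN(C)CCn1cnnc1-c1cc(Oc2ccc(NC(=O)N/N=C/c3ccccc3)cc2F)ccn1`: 2730 nM
Compound 2 `Cn1ncnc1-c1cc(Oc2ccc(NC(=O)N/N=C/c3ccccc3)cc2F)ccn1`: > 100000 nM

In a functional assay on MKN-45 cells (Homo sapiens) for cytotoxicity, read by MTT assay, with a stated time of 72 h (on this read-out lower numbers stand for stronger inhibition and higher numbers for weaker inhibition), compound 1 gives 2730 nM. For compound 2 the reported > 100000 nM is a limit of the assay rather than a number; compound 2 sits at the limit of > 100000 nM in this assay, at which 1 of the 2 values shown sits. Going by the values given here, the only measured step is an at least 36-fold higher number from compound 1 to compound 2 (1.56 log units; beyond the scatter). Compound 3 `Cn1cnnc1-c1cc(Oc2ccc(NC(=O)N/N=C/c3ccccc3)cc2F)ccn1` differs from compound 2 by 4-methyl-4H-1,2,4-triazol-3-yl in place of 1-methyl-1H-1,2,4-triazol-5-yl on an aromatic carbon, so compound 3 shares the triazole attachment of compound 1 but carries a methyl. Given the large step of an at least 36-fold higher number from compound 1 to compound 2 (1.56 log units; beyond the scatter), a partial return is expected, and for compound 3 a step of an at least 5.0-fold lower number from compound 2 to compound 3 (0.69 log units; beyond the scatter) is expected. Compound 3 is estimated at 20000 nM, between 4000 nM and 100000 nM.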

Compound 3, half-maximal inhibitory concentration: 7610 nM
For compound 3 the middle estimate is 2.6-fold (0.42 log units) above the measured one; the measured number falls inside the stated range.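

With the same atoms joined differently, 4-methyl-4H-1,2,4-triazol-3-yl in place of 1-methyl-1H-1,2,4-triazol-5-yl gives an at least 13-fold lower number from compound 2 to compound 3 (1.11 log units; beyond the scatter) in this assay, so the way the triazole is joined matters on its own; this step starts from a limit of the assay: the limit of > 100000 nM in this assay, at which 1 of the 3 values shown sits.

The earlier step changed attachment and side chain together. With the attachment held, hydrogen in place of (dimethylamino)methyl gives a 2.8-fold higher number from compound 1 to compound 3 (0.45 log units; beyond the scatter), a modest step set against the large one for the attachment.

Open, going by these compounds, is whether the lower number of compound 1 needs the dimethylamino group, or would also come with a morpholine, a carboxylic acid or a longer chain in its place.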